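From 4-fluorophenyl to pyrimidin-5-yl on the shared core

The source may hold more compounds than are shown below. What is called first, only, known or untested is meant among the compounds shown, and "the series" means these compounds.

Values in an ADME assay on L6 cells (Rattus norvegicus) for cytotoxicity, read by fluorescence and resazurin assay, with a stated time of 72 h; on this read-out lower numbers stand for an effect already at smaller amounts and higher numbers for an effect only at larger amounts of compound
Compound 1 `Cc1ccncc1-c1ccc2[nH]c(=O)nc(-c3ccccc3)c2c1` gives > 50000 nM (a limit, not a number)
Compound 2 `O=c1nc(-c2ccccc2)c2cc(-c3ccccc3F)ccc2[nH]1` gives 55800 nM
Compound 3 `O=c1nc(-c2ccccc2)c2cc(-c3ccc(F)cc3)ccc2[nH]1` gives 50000 nM

Among the compounds with values here, compound 3 (50000 nM) holds one of only two readable numbers in this assay, and it sits level with compound 2 within the scatter. Compound 4 `O=c1nc(-c2ccccc2)c2cc(-c3cncnc3)ccc2[nH]1` keeps the shared core and carries pyrimidin-5-yl in place of 4-fluorophenyl on an aromatic carbon.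

Within the data shown here, the only readable step exchanges 2-fluorophenyl for 4-fluorophenyl (a 1.1-fold lower number from compound 2 to compound 3 (0.05 log units; within the scatter)). The two other steps start from a limit and give no size (a step that the limit leaves unreadable from compound 1 to compound 2; a number no higher from compound 1 to compound 3 (the limit leaves the size open)). Compound 1 carries 4-methylpyridin-3-yl on that carbon and stands at a limit (> 50000 nM). This is the closest guide to a ring containing nitrogen, although it is not a measured size.

No step beyond the scatter is therefore expected, with a slight lean towards a higher number (a 1.2-fold higher number from compound 3 to compound 4 (0.08 log units; within the scatter)). A result reported only as a limit would not be surprising. For compound 4 the estimated value is 60000 nM (expected range 35000 nM to 100000 nM).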

Compound 4, half-maximal effective concentration: > 50000 nM
Compound 4 gave a limit, no number; the forecaster's own chance of this, stated with the estimate: 45%; the middle value is on the limit's open side.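

In this assay compound 4 gives > 50000 nM, which is a limit and not a number. Placing pyrimidin-5-yl on this aromatic carbon in place of 4-fluorophenyl produces a number no lower from compound 3 to compound 4 (the limit leaves the size open), so a ring with two nitrogen atoms and two hydrogen-bond acceptors does not bring the number down from the level of the fluorophenyl compound. The steps to compound 4 from compound 1 and from compound 2 cannot be read, which leaves no size for any nitrogen-containing ring at this position, only a shared result for compound 1 and compound 4: the limit of > 50000 nM in this assay, at which 2 of the 4 values shown sit.

The compounds shown leave open whether a group of another kind on this aromatic carbon, such as an amine or a carboxylic acid, would give a readable number clearly lower than those of compound 2 and compound 3. They also leave open how far beyond the limit compound 1 and compound 4 lie, and whether the two differ from each other at all.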